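Swapping the Ring on the Core Nitrogen

The source may report more compounds than this note shows. Statements on the series, on what has been measured and on what is new or still open speak of the compounds shown alone.

Of the compounds shown here, three built on one shared core have been tested in a functional assay on BGC-823 cells (Homo sapiens) for inhibition, read by CCK-8 assay, with a stated time of 48 h; a higher number here means a weaker inhibitor, a lower number a stronger inhibitor. Compound 1 `Cc1ccc(C2=NN(C3=NC(c4ccccc4)CS3)C(c3ccc4ccccc4c3)C2)cc1` gives 8940 nM, compound 2 `Fc1ccc(C2=NN(C3=NC(c4ccccc4)CS3)C(c3ccc4ccccc4c3)C2)cc1` gives 17300 nM, and compound 3 `O=C1CSC(N2N=C(c3ccc(Br)cc3)CC2c2ccc3ccccc3c2)=N1` gives 11700 nM. Compound 3 stands second highest of the three numbers, but its gaps to compound 1 and to compound 2 both lie within the scatter. Among the measured compounds shown here, the only single-point step measured, a 1.9-fold higher number from compound 1 to compound 2 (0.29 log units; within the scatter), was likewise within the scatter. Compound 4 `Brc1ccc(C2=NN(C3=NC(c4ccccc4)CS3)C(c3ccc4ccccc4c3)C2)cc1` differs from compound 3 by a group of 11 heavy atoms (9 carbon, 1 nitrogen, 1 sulfur; one five-membered non-aromatic ring with 2 hetero atoms, one six-membered aromatic ring of carbon only) in place of a group of 6 heavy atoms (3 carbon, 1 nitrogen, 1 oxygen, 1 sulfur; one five-membered non-aromatic ring with 2 hetero atoms), on an amine nitrogen in a ring. For the measured compounds named here, no measured step covers this swap; compound 4 keeps the 4-bromophenyl group of compound 3 and carries the entering ring of compounds 1 and 2, whose numbers sit close together. The expected step is therefore a 1.0-fold higher number from compound 3 to compound 4 (0.01 log units; within the scatter). Compound 4 is estimated at 12000 nM, within 5000 nM to 30000 nM.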

Compound 4, half-maximal inhibitory concentration: 13000 nM
Beside the measured number, compound 4's estimate is 1.1-fold (0.03 log units) below it; the range from low to high includes it.
By their numbers in this assay, from the lowest: compounds 1, 3, 4 and 2 (each within the scatter of the next).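

In this assay, the step for the ring swap on the amine nitrogen in a ring is a 1.1-fold higher number from compound 3 to compound 4 (0.05 log units; within the scatter), so the added six-membered aromatic ring leaves the number unchanged within the scatter. On the aromatic carbon of the other end, bromo in place of fluoro gives a 1.3-fold lower number from compound 2 to compound 4 (0.12 log units; within the scatter) and bromo in place of methyl gives a 1.5-fold higher number from compound 1 to compound 4 (0.16 log units; within the scatter), so these three groups also stay within the scatter of each other. No supporting measurement bears on these results. Still open, as far as these compounds go, is whether an amine or a carboxylic acid on that aromatic carbon would give a step beyond the scatter.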